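Indolinone series: hydroxy to chloro swap on compound 1

The source may report more compounds than this note shows. Statements on the series, on what has been measured and on what is new or still open speak of the compounds shown alone.

Measured so far:
compound 1 `COc1cc2c(/C=C3/C(=O)Nc4ccc(O)cc43)c(Cl)n(Cc3cc(OC)c(OC)c(OC)c3)c2cc1C` — 2040 nM
compound 2 `O=C1Nc2ccccc2/C1=C\c1c(Cl)n(Cc2ccccc2)c2ccccc12` — 16600 nM

Going by the values given here, in a functional assay on cells (Cancer cell lines, Homo sapiens) for cytotoxicity, with a stated time of 48 h (a lower number here means a stronger inhibitor of growth, a higher number a weaker inhibitor of growth), compound 1 gives 2040 nM, the lower of the two numbers known so far. Among the compounds with values here, compound 2 gives 16600 nM in this assay, a gap from compound 1 that lies beyond the scatter; the two share only the core, and no single-point step between them is available.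

Compound 3 `COc1cc2c(/C=C3/C(=O)Nc4ccc(Cl)cc43)c(Cl)n(Cc3cc(OC)c(OC)c(OC)c3)c2cc1C` differs from compound 1 in one place: chloro in place of hydroxy on an aromatic carbon, the site being on an aromatic carbon of a six-membered aromatic ring of carbon only, part of a fused system of two rings, meta to a fused ring and para to a fused ring. Within the data shown here, no measured pair isolates this change, so the direction rests on no data. The expectation is a modest step of a 1.6-fold higher number from compound 1 to compound 3 (0.20 log units; within the scatter) toward a higher number, with a range wide enough to include no change beyond the scatter. Compound 3 is expected to give about 3200 nM in this assay, between 900 nM and 11000 nM.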

Compound 3, concentration for 50% growth inhibition: 2340 nM
Beside the measured number, compound 3's estimate is 1.4-fold (0.14 log units) above it; the measured number falls inside the stated range.
By their numbers in this assay, from the lowest: compounds 1 and 3 (each within the scatter of the next); then compound 2.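

In this assay, going by these compounds alone, the first single-point pair of the series gives a 1.1-fold higher number from compound 1 to compound 3 (0.06 log units; within the scatter) for chloro in place of hydroxy on this aromatic carbon, meta to a fused ring and para to a fused ring. At this site, the hydroxy with its 1 hydrogen-bond donor and 1 hydrogen-bond acceptor can therefore be exchanged for chloro, with 0 of each, without a difference beyond the scatter. No independent measurement is available to account for this result.

This single pair leaves open whether the site would accept a group of another kind, such as an amine or a carboxylic acid, with as little difference. On these data alone, it is also open whether the same exchange would give a comparable result with the other substituents of compound 1 changed.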